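Amino in place of nitro: the step to compound 3

The source may hold more compounds than are shown below. What is called first, only, known or untested is meant among the compounds shown, and "the series" means these compounds.

Measured so far:
compound 1 `CN1Cc2sc(N)cc2C(c2ccc(Br)cc2)C1` — 7.4 mg/kg
compound 2 `CN1Cc2sc([N+](=O)[O-])cc2C(c2ccc(Cl)cc2)C1` — limit only

In a functional assay on the whole organism with Mus musculus as the target (a lower number here means that less compound is needed, a higher number that more compound is needed for the effect), compound 1 gives 7.4 mg/kg. Compound 2 reaches only > 40 mg/kg, which is a limit of the assay and not a number. Compound 2 thus stands at the limit of > 40 mg/kg in this assay, at which 1 of the 2 values shown sits. Compound 3 `CN1Cc2sc(N)cc2C(c2ccc(Cl)cc2)C1` differs from compound 2 by amino in place of nitro on an aromatic carbon. Within the data shown here, no measured step covers this change. A move toward a lower dose, beyond the usual scatter, is expected, the step being estimated as an at least 5.0-fold lower number from compound 2 to compound 3 (0.69 log units; beyond the scatter). For compound 3 the estimate is 8 mg/kg, with a range from 3 mg/kg to 25 mg/kg. This estimate rests on compound 1, which carries the same amino group and gives 7.4 mg/kg.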

Compound 3, dose for half-maximal effect: > 40 mg/kg
Compound 3 ended at the assay's limit (the forecaster's own chance of this, stated with the estimate: 10%); middle value at least 5.0-fold (0.69 log units) from the limit.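

With the amino group kept, chloro in place of bromo on an aromatic carbon gives an at least 5.4-fold higher number from compound 1 to compound 3 (0.73 log units; beyond the scatter) in this assay, so amino alone does not secure a measurable dose here. Compound 3 gives > 40 mg/kg, a limit of the assay and not a number. The step for amino in place of nitro cannot be read, and the values gather at one limit: the limit of > 40 mg/kg in this assay, at which 2 of the 3 values shown sit.

Still open, on these data alone, is whether fluoro or methyl in place of bromo gives a measurable dose. Also open, as far as these compounds go, is how an acetamide in place of amino would behave with bromo retained.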